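A few compounds are considered here, and "the series" means these few. Any claim that something is new, unique, unknown or untested is made for them only; others in the source may bear on it.

Compound 1 `CCCCc1cc2cn(COCCO)c(=O)nc2o1` gives in a functional assay on HEL cells (Homo sapiens) (a higher number here means that more compound is tolerated, a lower number that less compound is tolerated), a value of > 200000 nM, which is a limit of the assay rather than a number.
Compound 2 `O=c1nc2occc2cn1COCCO` gives in this assay a value of > 200000 nM, again a limit of the assay.
Compound 3 `CCCCc1cc2cn(COCCO)c(O)nc-2n1` gives in this assay a value of > 200000 nM, also a limit of the assay.

Compound 1 and compound 2 share one core and differ in a single place: hydrogen in place of butyl on an aromatic carbon. Since both sit at a limit, the step that the two limits leave unreadable from compound 1 to compound 2. Compound 3 carries another core; the difference between the two cores is not broken down here. Compound 4 `OCCOCn1cc2ccnc-2nc1O` has not yet been measured. It differs from compound 3 by hydrogen in place of butyl on an aromatic carbon. This is the same kind of change as that from compound 1 to compound 2, although the place is not identical: in compound 1 the butyl sits on a five-membered aromatic ring with 1 oxygen, next to the ring oxygen, whereas in compound 3 it sits on a five-membered aromatic ring with 1 nitrogen, next to the ring nitrogen. Resting on (the limit of > 200000 nM in this assay, at which 3 of the 3 values shown sit), only a small step is expected, a step that the limit leaves unreadable from compound 3 to compound 4 in this assay. Compound 4 is therefore estimated to give 300000 nM, most probably reported once more as a limit only, with a range from 150000 nM to 1000000 nM.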

Compound 4, half-maximal cytotoxic concentration: > 200000 nM
Compound 4 ended at the assay's limit (the forecaster's own chance of this, stated with the estimate: 85%); the middle value lies beyond the limit too.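

Among these compounds, compound 3 and compound 4 both stand at a limit of this assay rather than at a number, so no step from one to the other can be read. Left open are the actual cytotoxic concentrations of all the compounds shown, and so whether hydrogen in place of butyl changes them at all: the limit of > 200000 nM in this assay, at which 4 of the 4 values shown sit.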